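This account rests on a few compounds, and the source may have more. Where it says the series, first, only, none or still open, it means among the compounds named here.

Three compounds with a shared core were tested in a functional assay on K562 cells (Homo sapiens) for antiproliferative activity, read by CCK-8 assay, with a stated time of 72 h; a higher number here means a weaker inhibitor of growth, a lower number a stronger inhibitor of growth; they differ only in the group carried by the sulfonamide nitrogen:

Compound 1 `CCCNS(=O)(=O)c1ccc(Nc2ncc3c(n2)N(C2CCCC2)[C@H](CC)C(=O)N3C)cc1` gives 548 nM.
Compound 2 `CC[C@@H]1C(=O)N(C)c2cnc(Nc3ccc(S(=O)(=O)NCCO)cc3)nc2N1C1CCCC1` gives 546 nM.
Compound 3 `CC[C@@H]1C(=O)N(C)c2cnc(Nc3ccc(S(=O)(=O)NCCCO)cc3)nc2N1C1CCCC1` gives 331 nM.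

Compound 3 has the lowest of the three numbers, but the gaps to its neighbours are small: a 1.6-fold lower number from compound 2 to compound 3 (0.22 log units; within the scatter) and a 1.7-fold lower number from compound 1 to compound 3 (0.22 log units; within the scatter) both fall within the usual scatter of repeated measurements, so the three compounds cannot be told apart with confidence.

Compound 4 `CC[C@@H]1C(=O)N(C)c2cnc(Nc3ccc(S(=O)(=O)NC)cc3)nc2N1C1CCCC1` is the next step from compound 3. The change is hydrogen in place of 2-hydroxyethyl on a saturated chain carbon bound to a sulfonamide nitrogen. All three measured steps concern this same chain and bear on the question: a 1.0-fold lower number from compound 1 to compound 2 (0.00 log units; within the scatter), a 1.7-fold lower number from compound 1 to compound 3 (0.22 log units; within the scatter) and a 1.6-fold lower number from compound 2 to compound 3 (0.22 log units; within the scatter), each within the scatter. Adding or moving a hydroxy on the chain, or lengthening it by one carbon, left the number close to unchanged. Shortening the chain all the way to methyl has no measured precedent here, and removes more than any of those steps did. I therefore expect a step of a 1.7-fold higher number from compound 3 to compound 4 (0.22 log units; within the scatter), toward a somewhat higher number, at about the edge of the scatter rather than far beyond it. Compound 4 is thus estimated to give 550 nM in this assay, with a likely range from 270 nM to 1100 nM.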

Compound 4, concentration for 50% growth inhibition: 222 nM
Compound 4: middle estimate off by 2.5-fold (0.39 log units), on the high side, and the stated range ends above it.
By their numbers in this assay, from the lowest: compounds 4, 3, 2 and 1 (each within the scatter of the next, the first and the last beyond it).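

In this assay, the sulfonamide chain can be cut from 3-hydroxypropyl down to methyl without any loss of growth inhibition (a 1.5-fold lower number from compound 3 to compound 4 (0.17 log units; within the scatter)), so neither the length of that chain nor its hydroxy group is needed to keep the number where it stands. Compared with the other two chains, methyl gives the first steps in this small set that lie beyond the scatter, both modest: one replaces the 2-hydroxyethyl chain (a 2.5-fold lower number from compound 2 to compound 4 (0.39 log units; beyond the scatter)) and the other replaces the propyl chain (a 2.5-fold lower number from compound 1 to compound 4 (0.39 log units; beyond the scatter)). Nothing available here explains why the shortest chain reads this way.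

The compounds shown leave open what happens when the methyl is removed as well, which would give a plain sulfonamide with no carbon on the nitrogen, and whether a second methyl on that nitrogen, as a dimethyl sulfonamide, would be tolerated. They also leave open how a chain ending in an amine or a carboxylic acid would compare with the hydroxy-ended chains and with the methyl of compound 4.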